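The compounds below may be only part of what the source reports. "The series", "measured", "known", "first", "only" and "open" are said of these compounds alone.

Compound 1, `COc1ccc(/C(=C(/CCCl)c2ccccc2)c2ccccc2)cc1`: in a functional assay on MDA-MB-231 cells (Homo sapiens) for cytotoxicity, read by MTT assay, with a stated time of 72 h (a higher number here means a weaker inhibitor, a lower number a stronger inhibitor), compound 1 reaches only a limit, > 50000 nM.
Compound 2, `CCOC(=O)C(=O)NCC/C(=C(\c1ccccc1)c1ccc(OC)cc1)c1ccccc1`: compound 2 likewise reaches only a limit, > 50000 nM.
Compound 3, `COc1ccc(/C(=C(/CCNC(=O)C(=O)NC2CCCCC2)c2ccccc2)c2ccccc2)cc1`: compound 3 gives 12200 nM.

Compound 3 is the only one of the three with a number in this assay; the other two sit at the limit of > 50000 nM in this assay, at which 2 of the 3 values shown sit. The measured steps are an at least 4.0-fold lower number from compound 1 to compound 3 (0.61 log units; beyond the scatter), an at least 4.0-fold lower number from compound 2 to compound 3 (0.61 log units; beyond the scatter) and a step that the two limits leave unreadable from compound 1 to compound 2.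

Compound 4, `COc1ccc(/C(=C(/CCNC(=O)C(=O)N2CCCC2)c2ccccc2)c2ccccc2)cc1`, is not yet measured. It differs from compound 3 in one place: pyrrolidin-1-yl in place of cyclohexylamino on a carbonyl carbon. The step that bears on it most closely is an at least 4.0-fold lower number from compound 2 to compound 3 (0.61 log units; beyond the scatter), which changed the substituent on the same carbonyl carbon and brought the number from a limit down to a value. Compound 4 gives up the cyclohexylamino that went in at that step and takes a smaller, donor-free group in its place. Going by the values given here, since the one change at this carbonyl that was measured moved the number by at least a modest step, the reverse kind of change is expected to move it back toward weaker, though the data do not show how far. Compound 4 is therefore estimated at 22000 nM, between 8000 nM and 50000 nM, which means an expected step of a 1.8-fold higher number from compound 3 to compound 4 (0.26 log units; within the scatter).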

Compound 4, half-maximal inhibitory concentration: 48600 nM
Estimate against measurement, compound 4: 2.2-fold (0.34 log units) below; measured number inside the range.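

In this assay, the change on this carbonyl carbon from cyclohexylamino to pyrrolidin-1-yl gives a 4.0-fold higher number from compound 3 to compound 4 (0.60 log units; beyond the scatter), so the number here depends on which nitrogen group is attached, not merely on a nitrogen group standing in place of ethoxy. Compound 4 also shows that a nitrogen group at this carbon does not by itself secure a step as clear as the one to compound 3: the listed steps are an at least 1.0-fold lower number from compound 2 to compound 4 (0.01 log units; that floor lies within the scatter) and an at least 1.0-fold lower number from compound 1 to compound 4 (0.01 log units; that floor lies within the scatter). Both of these remain floors and give no size for the change, because compounds 1 and 2 start from a limit and not from a number: the limit of > 50000 nM in this assay, at which 2 of the 4 values shown sit.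

The step from compound 3 to compound 4 changes the ring and removes the amide hydrogen together, so the compounds shown do not tell which of the two differences accounts for the weaker number. Cyclopentylamino would keep the amide hydrogen on a smaller ring, while piperidin-1-yl would lack that hydrogen on a six-membered ring, and either group could begin to separate the two.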